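The source may hold more compounds than are shown below. What is called first, only, known or untested is meant among the compounds shown, and "the series" means these compounds.

Of the compounds shown here, three have a solubility number so far in a physicochemical assay for solubility; a lower number here means a less soluble compound, a higher number a more soluble compound. Compound 2 `NC(=O)c1cccc(NC(=O)c2cccc3ccccc23)c1` gives 10 ug/mL in this assay. Compound 3 `NC(=O)c1ccccc1NC(=O)c1cc2cc([N+](=O)[O-])ccc2s1` gives 10 ug/mL, level with compound 2 at the digits recorded. Compound 1 `CC(C)(C)OC(=O)NCc1ccccc1NC(=O)c1cccc2ccccc12` gives 5 ug/mL; its gap to compound 2 falls within the scatter, so none of the three stands apart from the others. Compound 4 `COC(=O)c1cccc(NC(=O)c2cccc3ccccc23)c1` is not yet measured and differs from compound 2 in one place: methoxy in place of amino on a carbonyl carbon. Going by the values given here, no measured pair repeats this change, so the expected step rests on the series alone; a moderate downward step is expected, a 2.5-fold lower number from compound 2 to compound 4 (0.40 log units; beyond the scatter), though one that may stay within the scatter. Compound 4 is estimated at 4 ug/mL, with a range from 1.5 ug/mL to 12 ug/mL.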

Compound 4, solubility: < 5 ug/mL
Compound 4 was reported as a limit; the forecaster's own chance of this, stated with the estimate: 10%; the middle value does not contradict the limit.
By their numbers in this assay, from the lowest: compounds 1, 2 and 3 (each within the scatter of the next).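

In this assay compound 4 gives < 5 ug/mL, which is a limit of the assay and not a number. Going by these compounds alone, the first single-place step reads as an at least 2.0-fold lower number from compound 2 to compound 4 (0.30 log units; that floor lies within the scatter), so this change from carbamoyl to methoxycarbonyl need not exceed the scatter, though the limit leaves room for a larger step. Compound 4 alone carries such a limit: the limit of < 5 ug/mL in this assay, at which 1 of the 4 values shown sits.

Going by these compounds, the true size of the step stays open. Also open, on these data alone, is how a carboxylic acid or a methylamino group on the same carbonyl carbon would compare with amino and methoxy.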